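Swapping the Aryl Group on the Oxadiazole Ring

The compounds below may be only part of what the source reports. "The series", "measured", "known", "first", "only" and "open" are said of these compounds alone.

Compound 1 `Cc1cccc(-c2noc(COc3ccc(CCC(=O)O)cc3Cl)n2)c1`: 4580 nM in a functional assay on CHO cells for agonist activity at Free fatty acid receptor 1 (Homo sapiens), read by FLIPR and calcium flux, in the presence of a further agent that is not named here; a lower number here means that less compound is needed, a higher number that more compound is needed for the effect
Compound 2 `O=C(O)CCc1ccc(OCc2ncc(-c3cccc(Cl)c3)o2)cc1`: 47500 nM in this assay
Compound 3 `O=C(O)CCc1ccc(OCc2nc(-c3ccccc3Cl)no2)cc1`: 1200 nM in this assay

Among these three, compound 3 shows the lowest number in this assay; compound 1 lies beyond the scatter above it, and compound 2 lies far higher still. Compound 4 `CCc1ccc(-c2noc(COc3ccc(CCC(=O)O)cc3)n2)cc1` has not yet been measured. It differs from compound 3 in one place: 4-ethylphenyl in place of 2-chlorophenyl on an aromatic carbon. Among the measured compounds shown here, no measured pair shows this particular change, so its effect can only be guessed from the spread of the three numbers seen so far. A modest rise in this assay is expected, close to the edge of the scatter, so the expected step is a 1.8-fold higher number from compound 3 to compound 4 (0.26 log units; within the scatter). Compound 4 is therefore estimated at 2200 nM in this assay, with a likely range from 500 nM to 9000 nM.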

Compound 4, half-maximal effective concentration: 210 nM
For compound 4 the middle estimate is 10-fold (1.02 log units) above the measured one, outside the stated range (below it).
By their numbers in this assay, from the lowest: compound 4; then compound 3; then compound 1; then compound 2.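

With 4-ethylphenyl in place of 2-chlorophenyl on this aromatic carbon of the five-membered ring, this assay shows a 5.7-fold lower number from compound 3 to compound 4 (0.76 log units; beyond the scatter). Among the compounds shown here, the number at this position therefore depends clearly on which substituted phenyl group it carries, a dependence that no earlier pair could show. Nothing measured here accounts for the change.

From the compounds shown here alone, the chlorine leaves and the ethyl enters in one step, so the share of each stays open. How a plain phenyl or a propyl chain on that ring would read is also unresolved.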